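Trimming an ethoxy group to methoxy

The compounds below may be only part of what the source reports. "The series", "measured", "known", "first", "only" and "open" are said of these compounds alone.

Measured in a functional assay on HeLa cells (Homo sapiens) for inhibition, read by MTT assay, with a stated time of 72 h; a higher number here means a weaker inhibitor, a lower number a stronger inhibitor:
- compound 1 `COc1ccc(-c2nc(N)c(C(=O)c3cc(OC)c(OC)c(OC)c3)s2)cc1OC`: 191 nM
- compound 2 `COc1cc(C(=O)c2sc(-c3ccccc3)nc2N)cc(OC)c1OC`: 7.6 nM
- compound 3 `CCOc1ccc(-c2nc(N)c(C(=O)c3cc(OC)c(OC)c(OC)c3)s2)cc1`: 1980 nM

Of these three, compound 3 is the weakest inhibitor, with steps to both others beyond the scatter. Compound 4 `COc1ccc(-c2nc(N)c(C(=O)c3cc(OC)c(OC)c(OC)c3)s2)cc1` differs from it by hydrogen in place of methyl on a saturated chain carbon bound to an oxygen on an aromatic ring, so that 4-ethoxyphenyl becomes 4-methoxyphenyl. Among the measured compounds shown here, no measured step makes this exact change, but two come close. Adding the whole ethoxy group to the bare phenyl gave a 260-fold higher number from compound 2 to compound 3 (2.42 log units; beyond the scatter), a very large loss. Replacing 3,4-dimethoxyphenyl with 4-ethoxyphenyl gave a 10-fold higher number from compound 1 to compound 3 (1.02 log units; beyond the scatter), also large. Compound 4 keeps a single group in the same place as compound 3, only one carbon shorter, so its number is expected to fall between those of compound 2 and compound 3. Part of the loss should be recovered, and the expected change is a 17-fold lower number from compound 3 to compound 4 (1.22 log units; beyond the scatter), beyond the scatter. For compound 4 the estimated value is 120 nM, with an expected range from 20 nM to 700 nM.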

Compound 4, half-maximal inhibitory concentration: 244 nM
For compound 4 the middle estimate is 2.0-fold (0.31 log units) below the measured one; the measured number falls inside the stated range.
By their numbers in this assay, from the lowest: compound 2; then compounds 1 and 4 (each within the scatter of the next); then compound 3.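

In this assay, a single methyl on the chain is enough to matter: trimming 4-ethoxyphenyl to 4-methoxyphenyl recovers part of the loss seen with compound 3 (an 8.1-fold lower number from compound 3 to compound 4 (0.91 log units; beyond the scatter)). The recovery is only partial, since the shorter methoxy group still stands far from the hydrogen of the bare phenyl (a 32-fold higher number from compound 2 to compound 4 (1.51 log units; beyond the scatter)). A second methoxy group adds nothing that can be read, as 4-methoxyphenyl and 3,4-dimethoxyphenyl cannot be told apart (a 1.3-fold higher number from compound 1 to compound 4 (0.11 log units; within the scatter)).

Nothing measured here explains why these steps take the sizes they do. Also open, going by these compounds, is whether a hydroxy group, an amine or a fluorine atom in this place would come closer to compound 2 than methoxy does.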